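Swapping a Butyl Chain for a Pivaloyloxy Group

The compounds below may be only part of what the source reports. "The series", "measured", "known", "first", "only" and "open" are said of these compounds alone.

Compound 1, `CC(C)C(=O)OCOC(=O)N1CCN(C(=O)c2nc(Nc3cc(C4CC4)[nH]n3)c3cc(Cl)ccc3n2)C[C@H]1C`, gives 14% in an ADME assay on S9 fraction from liver (Rattus norvegicus), read by LC-MS, with a stated time of 60 min, at 37 degrees C; a higher number here means that more of the compound is left, a lower number that less of the compound is left.
Compound 2, `C[C@@H]1CN(C(=O)c2nc(Nc3cc(C4CC4)[nH]n3)c3cc(Cl)ccc3n2)CCN1C(=O)OCc1ccccc1`, gives 45.6% in this assay.
Compound 3, `CCCCCOC(=O)N1CCN(C(=O)c2nc(Nc3cc(C4CC4)[nH]n3)c3cc(Cl)ccc3n2)C[C@H]1C`, gives 63.9% in this assay.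

Compound 3 stands highest of the three measured compounds in this assay, so the most of it survives the incubation. The step of a number 18.3 percentage points higher from compound 2 to compound 3 (beyond the scatter) is modest, while the step of a number 49.9 percentage points higher from compound 1 to compound 3 (beyond the scatter) is large and beyond the scatter.

Compound 4, `C[C@@H]1CN(C(=O)c2nc(Nc3cc(C4CC4)[nH]n3)c3cc(Cl)ccc3n2)CCN1C(=O)OCOC(=O)C(C)(C)C`, is compound 3 with one change: ((tert-butyl)carbonyl)oxy in place of butyl on a saturated chain carbon bound to an oxygen next to a carbonyl group. The measured steps that bear on this are those in which the same position was varied. The most telling is a number 49.9 percentage points higher from compound 1 to compound 3 (beyond the scatter), where an (isopropylcarbonyl)oxy group, a close relative of the group entering in compound 4, was replaced by butyl and the remaining fraction rose sharply. The step of a number 31.6 percentage points higher from compound 1 to compound 2 (beyond the scatter) points the same way, with compound 1 lowest of all.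

Moving from compound 3 to compound 4 reverses that kind of change, so a large drop in this assay is expected. Compound 4 is therefore estimated to give 24%. The plausible span for compound 4 is expected to run from 8% to 48%. This corresponds to an expected step of a number 39.9 percentage points lower from compound 3 to compound 4 (beyond the scatter).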

Compound 4, percent of the compound remaining: 47%
Estimate against measurement, compound 4: 23 percentage points below; measured number inside the range.
By their numbers in this assay, from the lowest: compound 1; then compounds 2 and 4 (each within the scatter of the next); then compound 3.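

One added methyl carries the main lesson: methyl in place of hydrogen on a saturated chain carbon bound to a carbonyl carbon and two saturated chain carbons gives a number 33 percentage points higher from compound 1 to compound 4 (beyond the scatter) in this assay and shows that the low number of compound 1 is not shared by every group of this type. The ((tert-butyl)carbonyl)oxy group still falls short of butyl, with a number 16.9 percentage points lower from compound 3 to compound 4 (beyond the scatter) as the modest step, yet the change to it from phenyl gives a number 1.4 percentage points higher from compound 2 to compound 4 (within the scatter) and so leaves these two compounds level. This position therefore responds to small details of the entering group and not simply to whether a carbonyl-containing group is present, and no evidence here explains why.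

The compounds shown leave open whether the effect of the added methyl would hold for other groups at this place, such as a cyclohexyl ring or a longer chain like octyl, or for one carrying an amine. They also leave open what each compound turns into during the incubation, since the read-out counts only the compound that remains.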